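Cyano on the Outer Ring: Expected Solubility Gain

The compounds below may be only part of what the source reports. "The series", "measured", "known", "first", "only" and "open" are said of these compounds alone.

Compound 1, `O=[N+]([O-])c1ccc(-c2ccc(O[C@H]3O[C@H](CO)[C@@H](O)[C@H](O)[C@@H]3O)c(Cl)c2)cc1`: 117 ug/mL
Compound 2, `OC[C@H]1O[C@H](Oc2ccc(-c3ccc(Cl)c(Cl)c3)cc2Cl)[C@@H](O)[C@@H](O)[C@@H]1O`: 2.3 ug/mL
Compound 3, `OC[C@H]1O[C@H](Oc2ccc(-c3ccccc3)cc2Cl)[C@@H](O)[C@@H](O)[C@@H]1O`: 5.5 ug/mL

All three were measured in a physicochemical assay for solubility, measured as kinetic solubility, with a stated time of 15 h, at pH 7.4; a higher number here means a more soluble compound, a lower number a less soluble compound. Compound 3 stands second highest of the three numbers: the step of a 21-fold lower number from compound 1 to compound 3 (1.33 log units; beyond the scatter) shows how far it lies beneath compound 1, while the step of a 2.4-fold higher number from compound 2 to compound 3 (0.38 log units; beyond the scatter) places it modestly above compound 2. The new compound 4, `N#Cc1ccc(-c2ccc(O[C@H]3O[C@H](CO)[C@@H](O)[C@H](O)[C@@H]3O)c(Cl)c2)cc1`, differs from compound 3 in one place: cyano in place of hydrogen on an aromatic carbon. The measured step that bears most on this change is a 21-fold lower number from compound 1 to compound 3 (1.33 log units; beyond the scatter), since that step took a nitro group off the outer phenyl and lowered the number sharply, whereas the present step puts a cyano group onto that phenyl. The other step, a 2.4-fold higher number from compound 2 to compound 3 (0.38 log units; beyond the scatter), concerns chlorine atoms and bears less. A rise beyond the scatter is therefore expected in this assay, though the cyano group need not match the nitro group fully. Compound 4 is expected to climb by about a 7.3-fold higher number from compound 3 to compound 4 (0.86 log units; beyond the scatter) to an estimated 40 ug/mL, within a likely range from 10 ug/mL to 150 ug/mL.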

Compound 4, solubility: 192 ug/mL
Estimate against measurement, compound 4: 4.8-fold (0.68 log units) below; the whole stated range lies below it.
By their numbers in this assay, from the lowest: compound 2; then compound 3; then compounds 1 and 4 (each within the scatter of the next).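

In this assay, a cyano group alone on the aromatic carbon para to a large group gives a 35-fold higher number from compound 3 to compound 4 (1.54 log units; beyond the scatter), so this position responds strongly to this small change. Nitro and cyano cannot be told apart here, with a 1.6-fold higher number from compound 1 to compound 4 (0.22 log units; within the scatter), which shows that two different groups at this position can give values within the scatter of each other, while 4-cyanophenyl in place of 3,4-dichlorophenyl gives an 83-fold higher number from compound 2 to compound 4 (1.92 log units; beyond the scatter). Nothing measured here explains the size of these steps.

From the compounds shown here alone, it remains open whether a large rise needs a group like nitro or cyano, since an amine, a carboxylic acid or a methoxy group on the same carbon could land anywhere on this scale. Going by these compounds, it is also open whether a cyano group on another carbon of the outer ring would give a similar step.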